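Swapping Propyl for Cyclopropyl on a Shared Core

This account rests on a few compounds, and the source may have more. Where it says the series, first, only, none or still open, it means among the compounds named here.

Compound 1 `CCCn1c(=O)c(S(=O)(=O)c2ccc(F)cc2F)cc2cnc(Nc3ccc4[nH]ccc4c3)nc21` gives 1000 nM
Compound 2 `Cn1c(=O)c(S(=O)(=O)c2ccc(N)cc2F)cc2cnc(Nc3ccc4[nH]ccc4c3)nc21` gives 1500 nM

Both numbers come from a functional assay on K562 cells (Homo sapiens) for inhibition, read by trypan blue exclusion, with a stated time of 72 h; a lower number here means a stronger inhibitor, a higher number a weaker inhibitor. Compound 1 and compound 2 lie within the usual scatter of each other, so these two measurements cannot tell them apart. The next compound is compound 3 `O=c1c(S(=O)(=O)c2ccc(F)cc2F)cc2cnc(Nc3ccc4[nH]ccc4c3)nc2n1C1CC1`, which keeps the core of compound 1 but carries cyclopropyl in place of propyl on an aromatic nitrogen. For the measured compounds named here, no measured pair here shows this change, so there is no direct precedent for judging the size of the step. The expectation therefore starts from compound 1 at 1000 nM and is for no shift beyond the scatter in this assay. The estimated change is a 1.3-fold lower number from compound 1 to compound 3 (0.10 log units; within the scatter). For compound 3 the expected value is 800 nM, with an estimated range of 200 nM to 3000 nM.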

Compound 3, half-maximal inhibitory concentration: 500 nM
Estimate against measurement, compound 3: 1.6-fold (0.20 log units) above, within the range that was stated.
By their numbers in this assay, from the lowest: compounds 3, 1 and 2 (each within the scatter of the next, the first and the last beyond it).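

For the compounds shown here, this is the first pair of compounds that differ only at this aromatic nitrogen, and in this assay it gives a 2.0-fold lower number from compound 1 to compound 3 (0.30 log units; within the scatter) for cyclopropyl in place of propyl. Closing the chain into a three-membered ring, with the same number of heavy atoms, therefore leaves the two compounds indistinguishable in this measurement, so this position accepts either group without a shift that can be told from scatter. No measured evidence here bears on this result.

Going by these compounds, how a longer chain such as butyl, a larger ring such as cyclobutyl, or a chain carrying an amine would read at this aromatic nitrogen remains open. The pair also speaks only for the shared core with its (2,4-difluorophenyl)sulfonyl group, so the same swap could read differently with another group there.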